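The source may report more compounds than this note shows. Statements on the series, on what has been measured and on what is new or still open speak of the compounds shown alone.

Working notes on the series.

Of the compounds shown here, two of the shared core have been measured in a functional assay on PC-12 cells (Rattus norvegicus) for inhibition, read by MTT assay; a higher number here means that more compound is needed for the effect, a lower number that less compound is needed. Compound 1 `CC1(C)N(O)C(c2ccc(OCC(=O)NCCCC[C@H](N)C(=O)O)cc2)=[N+]([O-])C1(C)C` gives 98800 nM there. Compound 2 `CC1(C)N(O)C(c2ccc(OCCNC(=O)C[C@H](N)C(=O)O)cc2)=[N+]([O-])C1(C)C` gives 58200 nM in this assay. Among the two numbers, compound 2 holds the lower one, but its nearest neighbour is compound 1, and the gap between the two lies within the scatter, so no order between them can be claimed.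

Compound 3 `COC(=O)[C@@H](N)CC(=O)NCCOc1ccc(C2=[N+]([O-])C(C)(C)C(C)(C)N2O)cc1` has not yet been measured in this assay. It differs from compound 2 by methyl in place of hydrogen on an oxygen next to a carbonyl group; cut one bond further out, the difference reads as carboxy to methoxycarbonyl. Within the data shown here, no measured pair isolates this change, so nothing in the data points to a direction for it. The expectation is therefore a step of a 1.1-fold lower number from compound 2 to compound 3 (0.02 log units; within the scatter) in this assay, that is, none beyond the scatter in either direction. On that basis compound 3 is estimated at 55000 nM in this assay, with a range from 18000 nM to 170000 nM.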

Compound 3, half-maximal effective concentration: 55600 nM
For compound 3 the middle estimate is 1.0-fold (0.00 log units) below the measured one; the measured number falls inside the stated range.
By their numbers in this assay, from the lowest: compounds 3, 2 and 1 (each within the scatter of the next).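

The exchange of carboxy for methoxycarbonyl, with methyl in place of hydrogen on an oxygen next to a carbonyl group, gives a 1.0-fold lower number from compound 2 to compound 3 (0.02 log units; within the scatter) in this assay. Among these compounds, this is the first comparison that isolates a single place, and it shows that this exchange, which adds one heavy atom and removes the hydrogen from that oxygen, produces no step beyond the scatter. In this read-out, then, the hydrogen on that oxygen is not needed to keep the number within the scatter of the value for the carboxy compound, although nothing available accounts for this result.

The compounds shown leave open whether a group larger than methyl on the same oxygen, such as ethyl or benzyl, or a carboxamide in place of the methoxycarbonyl group, would also stay within the scatter. They also leave open whether the same exchange would read the same way on the longer chain of compound 1, and what replacing the neighbouring amino group with a hydrogen or an acetamide would do at this end of the molecule.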